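Vero Tolerance Notes: From Compound 2 to Compound 4

The compounds below may be only part of what the source reports. "The series", "measured", "known", "first", "only" and "open" are said of these compounds alone.

Of the compounds shown here, three of the shared core have been tested in an ADME assay on Vero cells (Chlorocebus sabaeus) for cytotoxicity, read by MTT assay, with a stated time of 96 h; a lower number here means that less compound is tolerated, a higher number that more compound is tolerated. Compound 1 `COc1cc(/N=C/c2ccc(F)cc2)ccc1-c1cnco1` gives 325000 nM, compound 2 `CCc1ccc(CNc2ccc(-c3cnco3)c(OC)c2)s1` gives 13600 nM, and compound 3 `COc1cc(NCc2cc(OC)c(OC)c(OC)c2)ccc1-c1cnco1` gives 41600 nM. Compound 2 therefore stands at the lowest of the three numbers; its gaps to compound 3 and to compound 1 both lie beyond the usual scatter, so compound 2 is the least tolerated of the set. Compound 4 `COc1cc(NCc2ccsc2)ccc1-c1cnco1` is next for this assay. It differs from compound 2 in one place: thiophen-3-yl in place of 5-ethylthiophen-2-yl on a saturated chain carbon bound to a nitrogen on an aromatic ring. Within the data shown here, no pair of measured compounds shows this change, so the expectation rests on the spread of the set alone. A moderate move toward a higher number is expected, a 2.6-fold higher number from compound 2 to compound 4 (0.41 log units; beyond the scatter). Compound 4 is estimated at 35000 nM, within 12000 nM to 100000 nM.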

Compound 4, half-maximal cytotoxic concentration: 181000 nM
For compound 4 the middle estimate is 5.2-fold (0.71 log units) below the measured one; measured number above the stated range.
By their numbers in this assay, from the lowest: compound 2; then compound 3; then compounds 4 and 1 (each within the scatter of the next).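

Among these compounds, on the saturated chain carbon bound to a nitrogen on an aromatic ring, thiophen-3-yl in place of 5-ethylthiophen-2-yl gives a 13-fold higher number from compound 2 to compound 4 (1.12 log units; beyond the scatter) in this assay, the first single-place step and a large one. This position can therefore shift how much compound is tolerated, although the step combines loss of the ethyl group with a change in the thiophene attachment point. Nothing measured here bears on the cause of this step. Which of the two changes carries the step stays open. Unsubstituted thiophen-2-yl and 5-ethylthiophen-3-yl at this position would separate them.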